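Nitro in Place of Methoxy: Expected Paw Edema Inhibition

The compounds below may be only part of what the source reports. "The series", "measured", "known", "first", "only" and "open" are said of these compounds alone.

Measured compounds:
compound 1 `COc1ccc(NCC(=O)Oc2ccc3c(C)cc(=O)oc3c2)cc1` — 37.2%
compound 2 `COc1ccccc1NCC(=O)Oc1ccc2c(C)cc(=O)oc2c1` — 26.6%

Both compounds were tested in a functional assay on the whole organism (strain Wistar albino) for inhibition, with Rattus norvegicus as the target, read by paw edema, with stated times of 30 min and 3 h, at a dose of 20 mg/kg by the oral route; a lower number here means less inhibition, a higher number more inhibition at the dose given (going by the name of the read-out). Compound 1 gives 37.2% in this assay, and compound 2 gives 26.6%. Among the compounds with values here, the one measured step, a number 10.6 percentage points lower from compound 1 to compound 2 (beyond the scatter), moves the methoxy from one position to another on the amine-bound ring. Compound 2 therefore stands at the lower of the two numbers, beyond the scatter below compound 1.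

Compound 3 `Cc1cc(=O)oc2cc(OC(=O)CNc3ccccc3[N+](=O)[O-])ccc12` has not yet been measured. It differs from compound 2 by nitro in place of methoxy on an aromatic carbon. Within the data shown here, no measured step bears directly on this change: the only step on record swaps the position of a methoxy, not the kind of group, and nothing in the data shows what a nitro does on this ring. Among the measured compounds shown here, with no comparable step to lean on, no change beyond the scatter is expected from compound 2 to compound 3, and the estimated step is a number 0.4 percentage points higher from compound 2 to compound 3 (within the scatter). Compound 3 is expected to give about 27% in this assay, within a range from 14% to 40%.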

Compound 3, a percentage reported as inhibition, in the whole organism at one dose (the size of the read-out at that dose, not a potency): 15.9%
Compound 3: the middle estimate sits 11.1 percentage points above what was measured; the range from low to high includes it.
By their numbers in this assay, from the lowest: compound 3; then compound 2; then compound 1.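

In this assay nitro in place of methoxy on an aromatic carbon, ortho to a large group, gives a number 10.7 percentage points lower from compound 2 to compound 3 (beyond the scatter) and so shows that the read-out responds to the kind of group at this position. The earlier step of a number 10.6 percentage points lower from compound 1 to compound 2 (beyond the scatter) came from a change in where the methoxy sits on the ring, and it could say nothing about exchanging that group for another. Nothing available explains the lower number for the nitro compound, as no supporting evidence bears on this change.

Going by these compounds, what an amine or a carboxylic acid would give at this same position remains open, so it cannot yet be said whether the lower number is particular to nitro or would follow from other replacements of methoxy here. Also open, on these data alone, is whether nitro in the place held by the methoxy of compound 1 would bring a step of similar size, which would show whether the effect of this exchange depends on where it is made on the ring.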